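This account rests on a few compounds, and the source may have more. Where it says the series, first, only, none or still open, it means among the compounds named here.

Compound 1 `Cc1ccc(C2CN(C)Cc3c(N)cccc32)cc1` is the reference point: in a functional assay on the whole organism for inhibition of sodium-dependent dopamine transporter (Mus musculus) (a lower number here means that less compound is needed, a higher number that more compound is needed for the effect), compound 1 gives about 22 mg/kg. Among the compounds with values here, compound 2 `CC(C)c1ccc(C2CN(C)Cc3c(N)cccc32)cc1` carries isopropyl in place of methyl on an aromatic carbon, and in this assay compound 2 gives about 65 mg/kg; the step of a 3.0-fold higher number from compound 1 to compound 2 (0.47 log units; beyond the scatter) is the only one measured between compounds that differ in a single place. Compound 3 `CCCNC(=O)Nc1cccc2c1CN(C)CC2c1ccccc1` differs from both of these in more than one place. For compound 3 this assay reports only a limit, > 120 mg/kg, and that is where compound 3 stands on the numbers shown (the limit of > 120 mg/kg in this assay, at which 1 of the 3 values shown sits). Compound 4 `CCNCC(=O)Nc1cccc2c1CN(C)CC2c1ccccc1` differs from compound 3 by (ethylamino)methyl in place of propylamino on a carbonyl carbon; the two are built from the same atoms, joined differently. Within the data shown here, no measured step touches this part of the molecule: the step from compound 1 to compound 2 concerns the aromatic substituent and says nothing about the carbonyl side. With compound 3 at the limit, the step that the limit leaves unreadable from compound 3 to compound 4 is expected to stay within the scatter, with no direction that the data support. Compound 4 is therefore estimated at 130 mg/kg, within 50 mg/kg to 350 mg/kg, with a substantial chance that this assay again returns only a limit.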

Compound 4, dose for half-maximal effect: about 60 mg/kg
The estimate for compound 4 lay 2.2-fold (0.34 log units) above the measured number, within the range that was stated.
By their numbers in this assay, from the lowest: compound 1; then compounds 4 and 2 (each within the scatter of the next). At a limit, above all of these: compound 3.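

In this assay, (ethylamino)methyl in place of propylamino on a carbonyl carbon whose other neighbour is an amide-type nitrogen gives an at least 2.0-fold lower number from compound 3 to compound 4 (0.30 log units; that floor lies within the scatter). Within the data shown here, this is the first reading at this position, as the earlier step concerned only the aromatic substituent, but the floor alone does not establish a real difference between the two groups, which have the same heavy atoms and differ in that the entering group carries 1 hydrogen-bond acceptor and the leaving group 0. The true size of the step stays unknown because compound 3 is held only as a limit: the limit of > 120 mg/kg in this assay, at which 1 of the 4 values shown sits.

Open, as far as these compounds go, is which part of the change carries the step: a plain butyl chain on the same carbonyl carbon, with no nitrogen in it, would separate the amine from the chain length, and (propylamino)methyl or (dimethylamino)methyl would test the amine itself. Also open, from the compounds shown here alone, is how (ethylamino)methyl behaves on the same carbonyl carbon when methyl or isopropyl stands on the aromatic carbon, as in the aromatic substitution of compound 1 and compound 2.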